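This account rests on a few compounds, and the source may have more. Where it says the series, first, only, none or still open, it means among the compounds named here.

Measured in a functional assay on L1210 cells (Mus musculus) for antiproliferative activity, read by MTT assay, with a stated time of 2 days; on this read-out higher numbers stand for weaker inhibition and lower numbers for stronger inhibition:
Compound 1 `O=C1c2ccccc2C(=O)N1C/C=C\Cn1cc(C#Cc2ccc(Br)cc2)c(=O)[nH]c1=O` gives 448000 nM.
Compound 2 `CCCCC#Cc1cn(C/C=C/CN2C(=O)c3ccccc3C2=O)c(=O)[nH]c1=O` gives 236000 nM.
Compound 3 `CCCCCC#Cc1cn(C/C=C/CN2C(=O)c3ccccc3C2=O)c(=O)[nH]c1=O` reaches only the assay limit, > 500000 nM.

In this assay compound 1 and compound 2 lie within the scatter of each other, so no order between them is claimed. Compound 3 stands at the limit of > 500000 nM in this assay, at which 1 of the 3 values shown sits. Among the compounds with values here, the single measured step, an at least 2.1-fold higher number from compound 2 to compound 3 (0.32 log units; beyond the scatter), concerns a saturated chain and is a different kind of change from the one now followed. Compound 4 `Cc1ccc(C#Cc2cn(C/C=C\CN3C(=O)c4ccccc4C3=O)c(=O)[nH]c2=O)cc1` differs from compound 1 by methyl in place of bromo on an aromatic carbon. Within the data shown here, no measured step covers an exchange on the aromatic ring, so no shift beyond the scatter is expected in this assay. Compound 4 is therefore expected to give about 420000 nM, with a range of 150000 nM to 1100000 nM. The step this estimate means is a 1.1-fold lower number from compound 1 to compound 4 (0.03 log units; within the scatter), an expected change within the scatter.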

Compound 4, half-maximal inhibitory concentration: 245000 nM
Compound 4: the middle estimate sits 1.7-fold (0.23 log units) above what was measured, within the range that was stated.
By their numbers in this assay, from the lowest: compounds 2, 4 and 1 (each within the scatter of the next). At a limit, above all of these: compound 3.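

In this assay, within the data shown here, the exchange of 4-bromophenyl for 4-methylphenyl gives the first measured step on the aromatic ring: a 1.8-fold lower number from compound 1 to compound 4 (0.26 log units; within the scatter). This aromatic carbon, para to a large group, therefore holds either bromo or methyl with no shift beyond the scatter, at least for this one pair. No measured property shown bears on this step.

From the compounds shown here alone, whether an amine or a carboxylic acid on this carbon would move the number beyond the scatter remains open. So does whether a group in another place on the ring would do so.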